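This account rests on a few compounds, and the source may have more. Where it says the series, first, only, none or still open, it means among the compounds named here.

Measured so far:
compound 1 `Cc1nn2c(-c3nc4c(C)c(C)ccc4[nH]3)c(-c3ccccc3)nc2s1`: > 30000 nM
compound 2 `Cc1nn2c(-c3nc4cc(Cl)ccc4[nH]3)c(-c3ccc(F)cc3)nc2s1`: 14400 nM

In a functional assay on DU-145 cells (Homo sapiens) for antiproliferative activity, read by MTT assay (on this read-out higher numbers stand for weaker inhibition and lower numbers for stronger inhibition), compound 1 gives only a limit, > 30000 nM, and not a number. In this assay compound 2 gives a number, 14400 nM. Compound 3 `Cc1ccc(-c2nc3sc(C)nn3c2-c2nc3c(C)c(C)ccc3[nH]2)cc1` differs from compound 1 by methyl in place of hydrogen on an aromatic carbon, phenyl to 4-methylphenyl (methyl in place of hydrogen on an aromatic carbon). Among the measured compounds shown here, no measured pair shows this change. No step beyond the scatter is expected in this assay, in either direction. The step expected is a number no higher from compound 1 to compound 3 (the limit leaves the size open). For compound 3 the estimated value is 30000 nM, with an expected range of 12000 nM to 60000 nM.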

Compound 3, half-maximal inhibitory concentration: 12500 nM
The estimate for compound 3 lay 2.4-fold (0.38 log units) above the measured number, and the stated range covers the measured number.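

In this assay, phenyl to 4-methylphenyl gives an at least 2.4-fold lower number from compound 1 to compound 3 (0.38 log units; beyond the scatter), so a single methyl at this place, para to a large group, is enough to move the read-out beyond the scatter. Among the compounds shown here, this is the first step that can be read at all, and it runs towards stronger inhibition. Compound 1 gives only a limit, so the step has a lower bound and no fixed size: the limit of > 30000 nM in this assay, at which 1 of the 3 values shown sits.

As far as these compounds go, whether an ethyl, a methoxy or an amine at this place would act like methyl stays open. So does whether the step carries over to a core with other substituents.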